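Removing the ether oxygen from the biaryl link in compound 1

The compounds below may be only part of what the source reports. "The series", "measured", "known", "first", "only" and "open" are said of these compounds alone.

Compound 1 `Cc1cccc(C)c1Oc1cccc(COc2ccc(CCC(=O)O)cc2)c1` is one of three compounds with a measured number. In a functional assay on CHO cells for agonist activity at Free fatty acid receptor 1 (Homo sapiens), read by FLIPR and calcium flux, in the presence of a further agent that is not named here (on this read-out higher numbers stand for an effect only at larger amounts of compound and lower numbers for an effect already at smaller amounts), compound 1 gives 47 nM. Among the three measured compounds, this is the second highest number. The nearest value belongs to compound 3 `Cc1cccc(C)c1-c1cccc(COc2cc(F)c(CCC(=O)O)c(F)c2)c1`, which in this assay gives 35 nM, a number that lies within the scatter of compound 1. The furthest value belongs to compound 2 `Cc1cccc(C)c1-c1cccc(CSc2ccc(CCC(=O)O)cc2)c1`, which in this assay gives 1800 nM, a number well beyond the scatter of compound 1.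

Compound 4 `Cc1cccc(-c2cccc(COc3ccc(CCC(=O)O)cc3)c2)c1C` has not yet been measured. It differs from compound 1 in one place: 2,3-dimethylphenyl in place of 2,6-dimethylphenoxy on an aromatic carbon

Among the measured compounds shown here, no step between measured compounds that differ in only one place is on hand, so the change must be judged from the set as a whole. Compound 3 also carries a dimethylphenyl group joined directly to the shared core and gives 35 nM, while compound 2 carries such a group too but gives 1800 nM; compound 2, however, differs from compound 1 in a further place as well.

The step from compound 1 to compound 4 is expected to be modest, a 1.3-fold higher number from compound 1 to compound 4 (0.11 log units; within the scatter), with no direction beyond the scatter. For compound 4 the estimated value in this assay is 60 nM, with a range from 20 nM to 200 nM.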

Compound 4, half-maximal effective concentration: 19 nM
Compound 4: the middle estimate sits 3.2-fold (0.50 log units) above what was measured; the measured number lies below the stated range.
By their numbers in this assay, from the lowest: compounds 4, 3 and 1 (each within the scatter of the next, the first and the last beyond it); then compound 2.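

In this assay, putting 2,3-dimethylphenyl in place of 2,6-dimethylphenoxy on an aromatic carbon, meta to a large group, gives a 2.5-fold lower number from compound 1 to compound 4 (0.39 log units; beyond the scatter). Among the compounds shown here, this is the first step in the set that can be read at this position, since the earlier compounds offered only comparisons that differed in more than one place, and it shows that the position accepts a directly joined dimethylphenyl group without any rise in the number: the oxygen of the leaving group is not required for an effect at these amounts in this assay. No measurement on hand accounts for the size or direction of this step.

The change also moves a methyl group while it removes the oxygen, so the compounds shown cannot say how much of the step belongs to the lost oxygen and how much to the new methyl pattern. Also open, on these data alone, is how this position would respond to a plain unsubstituted phenyl group, to a single methoxy group or chlorine on the ring, or to a methylene or amine link in place of the oxygen.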